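The source may report more compounds than this note shows. Statements on the series, on what has been measured and on what is new or still open speak of the compounds shown alone.

Compound 3 `CCCCNc1nc(N)nc2c1CCN(C(C)=O)C2` gives 0.4 uM in an assay on HEK293 cells for agonist activity at Toll-like receptor 8 (Homo sapiens), read by a luciferase reporter, with a stated time of 6 h; on this read-out higher numbers stand for an effect only at larger amounts of compound and lower numbers for an effect already at smaller amounts. Among the three compounds measured so far, that number is the second highest: compound 1 `CCCCNc1nc(N)nc2c1CCNC2`, which gives 0.6 uM, sits nearest, and the step of a 1.5-fold lower number from compound 1 to compound 3 (0.18 log units; within the scatter) lies within the scatter. Compound 2 `CCCCNc1nc(N)nc2c1CCN(C)C2` gives 0.2 uM, and the step of a 2.0-fold higher number from compound 2 to compound 3 (0.30 log units; within the scatter) also lies within the scatter. Within the data shown here, the one step beyond the scatter is a 3.0-fold lower number from compound 1 to compound 2 (0.48 log units; beyond the scatter).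

Compound 4 `CCCCNc1nc(N)nc2c1CCN(S(C)(=O)=O)C2` has not yet been measured. It differs from compound 3 in a single place: methylsulfonyl in place of acetyl on an amine nitrogen in a ring. Among the measured compounds shown here, the steps that bear on this change are those that vary the same amine nitrogen in a ring, namely a 1.5-fold lower number from compound 1 to compound 3 (0.18 log units; within the scatter) and a 2.0-fold higher number from compound 2 to compound 3 (0.30 log units; within the scatter), both within the scatter, together with the modest 3.0-fold lower number from compound 1 to compound 2 (0.48 log units; beyond the scatter). Since each exchange at this nitrogen has moved the number little, no step beyond the scatter is expected here. Compound 4 is therefore expected to give 0.4 uM, in the range 0.15 uM to 1.2 uM. The step this estimate means, no change at the digits printed from compound 3 to compound 4 (within the scatter), is expected to remain within the scatter.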

Compound 4, minimum effective concentration: 0.8 uM
Compound 4: the middle estimate sits 2.0-fold (0.30 log units) below what was measured; low and high end bracket the measured number.
By their numbers in this assay, from the lowest: compounds 2, 3, 1 and 4 (each within the scatter of the next, the first and the last beyond it).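

In this assay, methylsulfonyl on the amine nitrogen in a ring cannot be told apart from acetyl (a 2.0-fold higher number from compound 3 to compound 4 (0.30 log units; within the scatter)) or from hydrogen (a 1.3-fold higher number from compound 1 to compound 4 (0.12 log units; within the scatter)), so this nitrogen now carries a second group with a double bond to oxygen without a step beyond the scatter. Methyl now stands apart from methylsulfonyl as well as from hydrogen (a 4.0-fold higher number from compound 2 to compound 4 (0.60 log units; beyond the scatter)), although compound 3, with acetyl, stays within the scatter of all three other compounds and so goes against any clean separation. Nothing at hand gives a reason for these numbers. The compounds shown leave open how a longer alkyl chain, a benzyl group or a carboxylic acid on this nitrogen would read. They also leave open whether methyl's separation from hydrogen and methylsulfonyl would extend to an ethyl group.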